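Amino substituent variation on the shared sulfamate core

A few compounds are considered here, and "the series" means these few. Any claim that something is new, unique, unknown or untested is made for them only; others in the source may bear on it.

In an assay on HEK293 cells for inhibition of Steryl-sulfatase (Homo sapiens), tested at 0.1 uM (on this read-out higher numbers stand for a stronger effect at the one concentration tested and lower numbers for a weaker effect), compound 1 `CN(CCCN1CCCCC1)c1cccc(C(=O)N2CCc3ccc(OS(N)(=O)=O)cc3C2)c1` gives 24.1% and compound 2 `CCN(Cc1ccccn1)c1cccc(C(=O)N2CCc3ccc(OS(N)(=O)=O)cc3C2)c1` gives 6.5%, the lowest of the two numbers seen so far. Within the data shown here, the only measured step, a number 17.6 percentage points lower from compound 1 to compound 2 (beyond the scatter), shows that swapping the amino group at this position moves the read-out beyond the scatter. Compound 3 `CCCN(CCC)c1cccc(C(=O)N2CCc3ccc(OS(N)(=O)=O)cc3C2)c1` carries dipropylamino in place of ethyl((pyridin-2-yl)methyl)amino on an aromatic carbon, bringing in a group with no ring. Among the measured compounds shown here, that single step is the only guide, and it gives no direction for such a group. The expected step is a number 3.5 percentage points higher from compound 2 to compound 3 (within the scatter), small. Compound 3 is expected to give 10%, within 0% to 25%.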

Compound 3, a percentage reported as inhibition, at one concentration (the size of the read-out at that concentration, not a potency): 8.3%
Compound 3: the middle estimate sits 1.7 percentage points above what was measured; the range from low to high includes it.
By their numbers in this assay, from the lowest: compounds 2 and 3 (each within the scatter of the next); then compound 1.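

In this assay, ring-free dipropylamino in place of ethyl((pyridin-2-yl)methyl)amino gives no change beyond the scatter (a number 1.8 percentage points higher from compound 2 to compound 3 (within the scatter)), so at this position losing that aromatic ring does not separate the two groups. Against methyl(3-(piperidin-1-yl)propyl)amino the drop is clear (a number 15.8 percentage points lower from compound 1 to compound 3 (beyond the scatter)), which leaves that group alone above the other two. Nothing at hand explains either step.

Open, on these data alone, is whether the higher read-out goes with the piperidine ring or with the propyl chain carrying it. A morpholine ring or a dimethylamino group at the end of that chain would test this.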